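The source may report more compounds than this note shows. Statements on the series, on what has been measured and on what is new or still open speak of the compounds shown alone.

Measured so far in a functional assay on KB cells (Homo sapiens) for inhibition, read by sulforhodamine B assay, with a stated time of 72 h; a lower number here means a stronger inhibitor of growth, a higher number a weaker inhibitor of growth:
Compound 1 `COC1CN(C(=O)/C=C/c2ccncc2-c2ccc3ccccc3c2)C1` gives > 10000 nM, a limit of the assay.
Compound 2 `Cn1ccc2cc(-c3cnccc3/C=C/C(=O)O)ccc21` gives > 10000 nM, a limit of the assay.
Compound 3 `O=C(/C=C/c1ccncc1-c1ccc2cc[nH]c2c1)N1CCOCC1` gives > 10000 nM, a limit of the assay.

Compound 1 therefore stands at the limit of > 10000 nM in this assay, at which 3 of the 3 values shown sit, with no number of its own; the other two measured compounds sit at the same limit. Within the data shown here, no pair among the three differs in one place, so no measured step in this assay is available.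

Compound 4 `CCOC(=O)/C=C/c1ccncc1-c1ccc2ccccc2c1` differs from compound 1 by ethoxy in place of 3-methoxyazetidin-1-yl on a carbonyl carbon, the (3-methoxyazetidin-1-yl)carbonyl becoming ethoxycarbonyl. In this assay the step is expected to be none beyond the scatter, with compound 4 most likely reported as a limit again. Compound 4 is estimated at 10000 nM, between 3000 nM and 30000 nM, an expected step of a number no higher from compound 1 to compound 4 (the limit leaves the size open).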

Compound 4, concentration for 50% growth inhibition: > 10000 nM
Compound 4: no number, only a limit (the forecaster's own chance of this, stated with the estimate: 70%); the middle value lies on the limit itself.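

Compound 1 and compound 4 both give only a limit in this assay, so no step between them can be read: the limit of > 10000 nM in this assay, at which 4 of the 4 values shown sit.

The compounds shown leave open whether any group on that carbonyl carbon gives measurable growth inhibition.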